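A few compounds are considered here, and "the series" means these few. Any claim that something is new, unique, unknown or untested is made for them only; others in the source may bear on it.

Compound 1 `COc1cccc(CNCCCNc2ccnc3cc(-c4ccc(C(C)(C)C)cc4)ccc23)c1O` in a physicochemical assay for solubility, with a stated time of 18 h, at pH 7.4 (on this read-out lower numbers stand for lower solubility and higher numbers for higher solubility), gives 32000 nM. Compound 2 `CC(C)(C)c1ccc(-c2ccc3c(NCCCNCc4ccco4)ccnc3c2)cc1` gives 32000 nM, and compound 3 `COc1cccc(CNCCCNc2ccnc3cc(-c4cc(C(F)(F)F)cc(C(F)(F)F)c4)ccc23)c1O` gives 32000 nM, so compound 1 stands level with both at the digits shown. Within the data shown here, the only step measured inside the set, no change at the digits printed from compound 1 to compound 2 (within the scatter), sits on a saturated chain carbon bound to an amine nitrogen, not on the core. Compound 4 `CCC(CC)c1ccc2c(NCCCNCc3cccc(OC)c3O)ccnc2c1` differs from compound 1 on the core instead: pentan-3-yl in place of 4-(tert-butyl)phenyl on an aromatic carbon. Among the measured compounds shown here, no measured step touches this position, and the three values offer no spread from which a direction could be read. The change is therefore expected to leave this assay unmoved beyond the scatter, an expected step of no change at the digits printed from compound 1 to compound 4 (within the scatter). Compound 4 is expected near 32000 nM, within 14000 nM to 64000 nM.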

Compound 4, solubility: 4200 nM
The estimate for compound 4 lay 7.6-fold (0.88 log units) above the measured number; measured number below the stated range.
By their numbers in this assay, from the lowest: compound 4; then compounds 1, 2 and 3 (each within the scatter of the next).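

Among these compounds, the aromatic carbon on the core responds in this assay, with a 7.6-fold lower number from compound 1 to compound 4 (0.88 log units; beyond the scatter) as the first change beyond the scatter in this set; the chain-carbon step gave no change at the digits printed from compound 1 to compound 2 (within the scatter). Here 4-(tert-butyl)phenyl, with 10 heavy atoms and one aromatic ring, gives way to pentan-3-yl, with 5 heavy atoms and no ring, so ring loss and atom count change together. No available evidence accounts for this step.

On these data alone, the separate contributions of the ring and the atom count remain open. A cyclohexyl or unsubstituted phenyl group at this position would help separate them.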